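Aryl variation on the triazole of the shared core

The source may report more compounds than this note shows. Statements on the series, on what has been measured and on what is new or still open speak of the compounds shown alone.

Measured compounds:
compound 1, `CC1(C)[C@H]2CC[C@]1(C)N(Cc1cn(-c3ccc(F)cc3)nn1)C(=O)C2`: 40 nM
compound 2, `CC1(C)[C@H]2CC[C@]1(C)N(Cc1cn(-c3ccccc3)nn1)C(=O)C2`: 50 nM
compound 3, `CC1(C)[C@H]2CC[C@]1(C)N(Cc1cn(-c3cccc(O)c3)nn1)C(=O)C2`: 410 nM

In a functional assay on LoVo cells (Homo sapiens) for inhibition, read by MTT assay, with a stated time of 24 h (on this read-out higher numbers stand for weaker inhibition and lower numbers for stronger inhibition), compound 1 gives the lowest of the three numbers. Compound 2 sits nearest, a 1.3-fold higher number from compound 1 to compound 2 (0.10 log units; within the scatter), so the two are not separable. Compound 3 sits furthest, a 10-fold higher number from compound 1 to compound 3 (1.01 log units; beyond the scatter), and the pair compound 2 to compound 3 shows the same picture, an 8.2-fold higher number from compound 2 to compound 3 (0.91 log units; beyond the scatter).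

Compound 4, `Cc1ccccc1-n1cc(CN2C(=O)C[C@@H]3CC[C@@]2(C)C3(C)C)nn1`, is not yet measured. Its change from compound 1: 2-methylphenyl in place of 4-fluorophenyl on an aromatic nitrogen.

Bearing on this: the step from compound 1 to compound 2 shows that losing the fluoro on the aromatic carbon costs nothing beyond the scatter, so the departure of 4-fluorophenyl itself is not expected to matter. The step from compound 2 to compound 3 shows a modest loss when a hydroxy enters on an aromatic carbon, but nothing measured carries a methyl, and the 2-methylphenyl has no hydroxy. Going by the values given here, no measured step covers this substitution directly.

The expectation is therefore a step within the scatter for compound 4, a 1.8-fold higher number from compound 1 to compound 4 (0.24 log units; within the scatter), leaning slightly toward a higher number. Compound 4 is estimated at 70 nM, range 25 nM to 250 nM.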

Compound 4, half-maximal inhibitory concentration: 80 nM
Estimate against measurement, compound 4: 1.1-fold (0.06 log units) below; low and high end bracket the measured number.
By their numbers in this assay, from the lowest: compounds 1, 2 and 4 (each within the scatter of the next); then compound 3.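

In this assay, 2-methylphenyl on the aromatic nitrogen stays level with 4-fluorophenyl, a 2.0-fold higher number from compound 1 to compound 4 (0.30 log units; within the scatter), and with plain phenyl, a 1.6-fold higher number from compound 2 to compound 4 (0.20 log units; within the scatter), so a methyl on the aryl ring is tolerated here as well as a fluoro. Against 3-hydroxyphenyl the picture differs, a 5.1-fold lower number from compound 3 to compound 4 (0.71 log units; beyond the scatter), which leaves compounds 1, 2 and 4 as one group within the scatter, with compound 3 the only one of the four that goes against it. No measurement of any other kind accompanies these numbers, so the data give no account of what lies behind this split.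

The compounds shown leave open whether the loss seen with compound 3 belongs to the hydroxy itself or to its place on the ring, a question that 2-hydroxyphenyl, 4-hydroxyphenyl or 3-methoxyphenyl would address. They also leave open how an aryl ring carrying an amine or a carboxylic acid would behave, and whether 4-methylphenyl would stay with compounds 1, 2 and 4.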